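The compounds below may be only part of what the source reports. "The series", "measured", "known", "first", "only" and "open" are said of these compounds alone.

In a physicochemical assay for lipophilicity, using potentiometric titration, at pH 7.4 (on this read-out higher numbers stand for higher lipophilicity and lower numbers for lower lipophilicity), compound 2 `Fc1ccc(-c2nc(-c3ccc(-c4ccccc4)cc3)no2)cc1F` gives 4.75, the higher of the two values on record. Compound 1 `Cc1ccc(-c2noc(-c3ccc(F)c(F)c3)n2)cn1` gives 3.07 in this assay, and the gap between compound 1 and compound 2 lies beyond the usual scatter of repeated measurements, so compound 2 stands clearly above it. Going by the values given here, no pair of measured compounds differs in a single place, so no measured step is available to guide the next move.

Compound 3 `Fc1ccc(-c2nc(-c3ccc(Br)cc3)no2)cc1F` has not yet been measured. It differs from compound 2 in one respect: bromo in place of phenyl on an aromatic carbon. On the basis of the gap between compound 1 and compound 2, the value of compound 3 is expected to fall below that of compound 2, and the step of a number 1.10 log units lower from compound 2 to compound 3 (beyond the scatter) is expected to exceed the scatter. Compound 3 is estimated to give about 3.65 in this assay, with a likely range from 3.2 to 4.1.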

Compound 3, distribution coefficient: 3.91
Estimate against measurement, compound 3: 0.26 log units below; the range from low to high includes it.
By their numbers in this assay, from the lowest: compound 1; then compound 3; then compound 2.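

In this assay, the change from phenyl to bromo on an aromatic carbon, para to a large group, gives a number 0.84 log units lower from compound 2 to compound 3 (beyond the scatter). Going by these compounds alone, this is the first step on record in which only one place changes, so it shows that the read-out depends on the group at this position even with the rest of the structure held constant. The step swaps 6 heavy atoms and a six-membered aromatic ring for 1 heavy atom, and no measurement on record explains its size.

The compounds shown leave open how an amine, a carboxylic acid or a longer chain at this same place would read in this assay. With a single step at this position, they also cannot establish any trend across groups there.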